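A Long Chain Ending in Sulfanyl Instead of Methyl

The source may hold more compounds than are shown below. What is called first, only, known or untested is meant among the compounds shown, and "the series" means these compounds.

Measured compounds:
compound 1, `COc1ccccc1C(=O)Nc1cn(C)nc1-c1ccccn1`, 130000 nM
compound 2, `CCCCCCCCCCCC(=O)Nc1cn(C)nc1-c1ccccn1`, > 150000 nM

Both compounds were tested in a functional assay on U-87MG ATCC cells (Homo sapiens) for cytotoxicity, read by MTT assay, with a stated time of 24 h; on this read-out higher numbers stand for weaker inhibition and lower numbers for stronger inhibition. Compound 1 gives 130000 nM. For compound 2 only a limit of this assay is reported, > 150000 nM, which is the limit of > 150000 nM in this assay, at which 1 of the 2 values shown sits. Compound 3, `Cn1cc(NC(=O)CCCCCCCCCCS)c(-c2ccccn2)n1`, differs from compound 2 by one change: sulfanyl in place of methyl on a saturated chain carbon, ten or more bonds along the chain from a carbonyl carbon. Going by the values given here, no measured pair shows this change, so its size is unknown; the expectation is a step no larger than the usual scatter, with compound 3 probably again reported only as a limit. Compound 3 is estimated at 150000 nM, within 60000 nM to 400000 nM. The expected step is a number no higher from compound 2 to compound 3 (the limit leaves the size open).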

Compound 3, half-maximal inhibitory concentration: > 150000 nM
Compound 3 gave a limit, no number; the forecaster's own chance of this, stated with the estimate: 60%; the middle value lies on the limit itself.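

Compound 2 and compound 3 are both reported only as limits in this assay, so no step can be read between them: the limit of > 150000 nM in this assay, at which 2 of the 3 values shown sit.

As far as these compounds go, whether sulfanyl in place of methyl on the long chain changes cytotoxicity at all remains open.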